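Sulfonyl piperidine series: cytotoxicity in HCT-116 cells

A few compounds are considered here, and "the series" means these few. Any claim that something is new, unique, unknown or untested is made for them only; others in the source may bear on it.

Compound 1 `CCCC(=O)N(Cc1ccccc1)C1CCN(S(=O)(=O)c2c(C)cc(C)cc2C)CC1`, compound 2 `CC1CCN(C2CCN(S(=O)(=O)c3cccc(-c4ccc5ccccc5c4)c3)CC2)CC1` and compound 3 `CC1CCN(C2CCN(S(=O)(=O)c3ccccc3-c3ccccc3)CC2)CC1` were tested in an ADME assay on HCT-116 cells (Homo sapiens) for cytotoxicity, read by CellTiter-Glo, with a stated time of 72 h; a higher number here means a weaker inhibitor, a lower number a stronger inhibitor. Compound 1 is reported only as a limit, > 5000 nM. Compound 2 likewise gives only a limit, > 5000 nM. Compound 3 too returns only a limit, > 5000 nM. Among the compounds with values here, compound 2 thus sits at the assay limit (the limit of > 5000 nM in this assay, at which 3 of the 3 values shown sit), and no measured step separates it from another compound. Compound 4 `Cc1ccc(-c2cccc(S(=O)(=O)N3CCC(N4CCC(C)CC4)CC3)c2)cc1` differs from compound 2 by 4-methylphenyl in place of naphthalen-2-yl on an aromatic carbon. Within the data shown here, with no measured step available, the expected step that the limit leaves unreadable from compound 2 to compound 4 in this assay is judged to stay within the scatter. For compound 4 the expected result in this assay is 8000 nM, within 3000 nM to 30000 nM, most probably again reported only as a limit.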

Compound 4, half-maximal inhibitory concentration: > 5000 nM
Compound 4: only a limit was reported; the forecaster's own chance of this, stated with the estimate: 80%; the middle value lies beyond the limit too.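

Compound 2 and compound 4 both return only limits in this assay, so no step can be read between them: the limit of > 5000 nM in this assay, at which 4 of the 4 values shown sit.

Whether any change in this series shifts cytotoxicity stays open, as the compounds shown give no value inside the readable range.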